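Compound 3 to compound 4: isopropoxy replaces chloro

The source may report more compounds than this note shows. Statements on the series, on what has been measured and on what is new or still open speak of the compounds shown alone.

In an ADME assay on HT-29 cells (Homo sapiens) for cytotoxicity, read by MTT assay, with a stated time of 72 h (on this read-out higher numbers stand for weaker inhibition and lower numbers for stronger inhibition), compound 3 `COc1ccc(C2=C(c3cc(OC)c(OC)c(OC)c3)C(=O)C(O)C2)cc1Cl` gives < 1 ug/mL, which is a limit and not a number. Compound 2 `COc1ccc(C2=C(c3cc(OC)c(OC)c(OC)c3)C(=O)C(O)C2)cc1` gives < 1 ug/mL, likewise a limit. As far as these compounds go, the position of compound 3 is therefore known only as the limit of < 1 ug/mL in this assay, at which 2 of the 3 values shown sit, and how far its true value lies under that limit stays open.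

Compound 4 `COc1ccc(C2=C(c3cc(OC)c(OC)c(OC)c3)C(=O)C(O)C2)cc1OC(C)C` carries isopropoxy in place of chloro on an aromatic carbon, ortho to a methoxy group and meta to a large group (isopropoxy in place of chloro on an aromatic carbon).

Among the measured compounds shown here, the only measured step between closely matched compounds is a step that the two limits leave unreadable from compound 2 to compound 3, so it offers no size to carry over. For the measured compounds named here, compound 1 `COc1ccc(C2=C(c3cc(OC)c(OC)c(OC)c3)C(=O)C(OC(C)=O)C2)cc1OC(C)C`, the only measured compound with an isopropoxy group, gives > 100 ug/mL, also a limit. It is not a matched comparison, but this value leans the expectation towards weaker inhibition in this assay.

The expected result is an at least 3.0-fold higher number from compound 3 to compound 4 (0.47 log units; beyond the scatter), in the direction of weaker inhibition, with its size poorly fixed and a reading at a limit quite possible. Compound 4 is estimated at 3 ug/mL, with an expected range from 0.3 ug/mL to 50 ug/mL.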

Compound 4, half-maximal inhibitory concentration: > 100 ug/mL
Compound 4 was reported as a limit (the forecaster's own chance of this, stated with the estimate: 55%); middle value at least 33-fold (1.52 log units) away from the limit.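

On the aromatic carbon ortho to a methoxy group and meta to a large group, isopropoxy in place of chloro in this assay gives an at least 100-fold higher number from compound 3 to compound 4 (2.00 log units; beyond the scatter), and isopropoxy in place of hydrogen gives an at least 100-fold higher number from compound 2 to compound 4 (2.00 log units; beyond the scatter). Hydrogen and chloro both leave the read-out at the limit on the strong side, while isopropoxy takes it to the limit on the weak side, so this position does not tolerate every group, which the first pair alone could not show. Compound 1 carried isopropoxy together with the acetyl on the oxygen and could not separate the two, whereas compound 4 keeps the free hydroxyl of compound 2 and compound 3 and still reaches the weak end, so the isopropoxy change alone is enough and the acetyl is not required: the limit of > 100 ug/mL in this assay, at which 2 of the 4 values shown sit.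

The steps from compound 2 to compound 3 and from compound 1 to compound 4 each join two limits and cannot be read, so chloro against hydrogen and the effect of the acetyl have no size here. As far as these compounds go, whether ethoxy or an amine at this position would stay at the strong limit or follow isopropoxy remains open, as does how far the true values of compound 2, compound 3 and compound 4 lie from their limits.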